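The source may report more compounds than this note shows. Statements on the series, on what has been measured and on what is new or still open speak of the compounds shown alone.

Measured compounds:
- compound 1 `Cc1cccc(Cn2c(CN3CCN(C(=O)c4ccncc4)CC3)nc3ccccc32)c1` — 20.6%
- compound 2 `Cc1ccccc1Cn1c(CN2CCN(C(=O)C3CC3)CC2)nc2ccccc21` — 29.1%

In an assay on isolated protein for inhibition of aldehyde dehydrogenase 1A1 (Homo sapiens), read by spectrophotometry, tested at 10 uM (on this read-out lower numbers stand for less inhibition and higher numbers for more inhibition at the one concentration tested (going by the name of the read-out)), compound 1 gives 20.6%, and compound 2 gives 29.1%. The two numbers lie within the usual scatter of one another, so compound 1 cannot be told apart from compound 2 on this read-out; both show modest inhibition at the single concentration. Compound 2 differs from compound 1 in more than one place, so no single structural step can be read from the pair.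

Compound 3 `CCCC(=O)N1CCN(Cc2nc3ccccc3n2Cc2cccc(C)c2)CC1` has not yet been measured. It differs from compound 1 in one place: propyl in place of pyridin-4-yl on a carbonyl carbon. Among the compounds with values here, with no comparable step among the measured compounds, the account can only note that the shared core and the rest of the molecule are kept, and that the only change sits on a carbonyl carbon whose other neighbour is an amide-type nitrogen in a ring.

The step from compound 1 to compound 3 in this assay is expected to be small, a number 3.4 percentage points higher from compound 1 to compound 3 (within the scatter), with no direction that can be stated beyond the scatter. For compound 3 the estimated value is 24%, within a range from 8% to 40%.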

Compound 3, a percentage reported as inhibition, at one concentration (the size of the read-out at that concentration, not a potency): 79.1%
The estimate for compound 3 lay 55.1 percentage points below the measured number; measured number outside the range, above it.
By their numbers in this assay, from the lowest: compounds 1 and 2 (each within the scatter of the next); then compound 3.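

In this assay, the group on the carbonyl carbon whose other neighbour is an amide-type nitrogen in a ring proves to matter: with the rest of compound 1 kept, propyl in place of pyridin-4-yl gives a number 58.5 percentage points higher from compound 1 to compound 3 (beyond the scatter), a large step beyond the scatter. Within the data shown here, the earlier compounds offered no single change to read, so this is the first sign that the assay responds strongly to what sits at this position. It also shows that, within this pair, the six-membered aromatic ring with its one hetero atom is not required for inhibition at the one concentration tested, and no measurement at hand accounts for the size of the step.

This one step cannot separate the loss of pyridin-4-yl from the arrival of propyl, as the two come together in a single change. On these data alone, how a phenyl ring, an ethyl group or a longer chain such as pentyl would behave on the same carbonyl carbon remains open, as does whether the higher number for compound 3 would carry over into a measured potency.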